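Notes on a diaryl series in a topoisomerase binding assay

The source may hold more compounds than are shown below. What is called first, only, known or untested is meant among the compounds shown, and "the series" means these compounds.

Measured so far:
compound 1, `COc1ccc(-c2cc3ccccc3c(-c3ccc(O)cc3)n2)cc1` — 6.7%
compound 2, `COc1ccc(-c2cc3ccccc3c(-c3ccc(OC)cc3)n2)cc1` — 0%
compound 3, `COc1ccc(-c2cc3cc(C)ccc3c(-c3cccc(O)c3)n2)cc1OC` — 1.7%

All three measured compounds were tested in a binding assay on isolated protein for inhibition of DNA topoisomerase 1 (Homo sapiens), with a stated time of 30 min, tested at 100 uM; a lower number here means a weaker effect, a higher number a stronger effect of the compound at the concentration tested. Compound 1 gives 6.7% in this assay, and compound 2 gives 0%. The step of a number 6.7 percentage points lower from compound 1 to compound 2 (within the scatter) is made by methyl in place of hydrogen on an oxygen on an aromatic ring. Compound 3 gives 1.7%; its number and that of compound 2 lie within the scatter of each other, and so do its number and that of compound 1. The difference between the core of compound 3 and the core of compound 1 is not broken down here.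

Compound 4, `COc1cccc(-c2nc(-c3ccc(OC)c(OC)c3)cc3cc(C)ccc23)c1`, is not yet measured. It differs from compound 3 by methyl in place of hydrogen on an oxygen on an aromatic ring. This is the same change as from compound 1 to compound 2, and it occurs twice among the compounds shown. The measured instance of that change stayed within the scatter, and compound 3 starts from a low number, so little movement is expected.

In this assay compound 4 is expected at 1%, within 0% to 8%, which is a step of a number 0.7 percentage points lower from compound 3 to compound 4 (within the scatter) and rests on the step of a number 6.7 percentage points lower from compound 1 to compound 2 (within the scatter).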

Compound 4, a percentage reported as inhibition, at one concentration (the size of the read-out at that concentration, not a potency): 2.9%
Beside the measured number, compound 4's estimate is 1.9 percentage points below it; the range from low to high includes it.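

In this assay, the change from hydroxy to methoxy gives a number 1.2 percentage points higher from compound 3 to compound 4 (within the scatter). Set beside the earlier instance of the same change, the two steps do not differ: the same change on two cores in this assay, a number 6.7 percentage points lower (within the scatter) from compound 1 to compound 2 and a number 1.2 percentage points higher (within the scatter) from compound 3 to compound 4, 7.9 percentage points apart, within the scatter of two such steps Within these two pairs, the change carries from one core to the other without a step beyond the scatter, but all four numbers are small and come from a single concentration, so this does not show how the change would behave on a compound with a clear effect, nor does it give any potency.

The compounds shown carry only hydroxy or methoxy at this place, which leaves open whether an amine, a carboxylic acid or a longer chain such as propoxy would move the number beyond the scatter. No pair shown separates the contributions of the other differences between the core of compound 1 and the core of compound 3, so those also remain open.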